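Trimming the Methyl from the Amine of Compound 2

The compounds below may be only part of what the source reports. "The series", "measured", "known", "first", "only" and "open" are said of these compounds alone.

Going by the values given here, in a functional assay on HCT-8 cells (Homo sapiens) for antiproliferative activity, read by MTT assay, with a stated time of 48 h (on this read-out lower numbers stand for stronger inhibition and higher numbers for weaker inhibition), only two compounds have been measured so far. Compound 1 `COc1ccc(C(=O)c2ccc3c(c2)C=CC(C)(C)O3)c(NC(=O)CN(C)C)c1` gives 2420 nM, while compound 2 `CNCC(=O)Nc1cc(OC)ccc1C(=O)c1cc(OC)c(OC)c(OC)c1` gives 780 nM, the lower of the two numbers and a gap beyond the scatter of repeated measurements. The next compound, compound 3 `COc1ccc(C(=O)c2cc(OC)c(OC)c(OC)c2)c(NC(=O)CN)c1`, keeps the structure of compound 2 except for hydrogen in place of methyl on an amine nitrogen. Among the compounds with values here, the two measured compounds differ in more than one place, so no measured step shows what this change does in this assay. The expectation therefore starts from compound 2 at 780 nM. The expected 1.2-fold higher number from compound 2 to compound 3 (0.06 log units; within the scatter) stays within the scatter, with no firm direction. For compound 3 the estimated value is 900 nM, with an expected range from 320 nM to 2500 nM.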

Compound 3, half-maximal inhibitory concentration: 330 nM
The estimate for compound 3 lay 2.7-fold (0.44 log units) above the measured number, within the range that was stated.
By their numbers in this assay, from the lowest: compound 3; then compound 2; then compound 1.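

Hydrogen in place of methyl on the amine nitrogen gives a 2.4-fold lower number from compound 2 to compound 3 (0.37 log units; beyond the scatter) in this assay, the first reading of a change at this position alone, since compound 1 and compound 2 differ in more than one place. On the shared core of compound 2 and compound 3, the methyl is therefore not required for activity, and the plain amino form gives the lower number by a margin beyond the scatter. No measurement at hand bears on why the number falls.

Going by these compounds, this rests on a single pair, so it remains open whether the same change would act alike on the core of compound 1. Also open, on these data alone, is how an ethyl group on this nitrogen, an acetyl group in its place, or a longer chain in place of aminomethyl would read.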